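The source may hold more compounds than are shown below. What is called first, only, known or untested is meant among the compounds shown, and "the series" means these compounds.

Measured compounds:
- compound 1 `Cc1nc(Nc2ccc(C(F)(F)F)c(Cl)c2)c2nc(Nc3c(Cl)cccc3Cl)sc2n1`: 3 nM
- compound 2 `CSc1nc(Nc2ccc(C(F)(F)F)c(Cl)c2)c2nc(Nc3c(Cl)cccc3Cl)sc2n1`: 224 nM
- compound 3 `CS(=O)(=O)c1nc(Nc2ccc(C(F)(F)F)c(Cl)c2)c2nc(Nc3c(Cl)cccc3Cl)sc2n1`: 274 nM

These three share one core and differ only in the group on one aromatic carbon of that core. In a functional assay on HEK293 cells for antagonist activity at transient receptor potential cation channel subfamily V member 1 (Homo sapiens), read by calcium flux (on this read-out higher numbers stand for weaker inhibition and lower numbers for stronger inhibition), compound 1 gives the lowest number of the three, and compound 3 gives the highest. The gap a 91-fold higher number from compound 1 to compound 3 (1.96 log units; beyond the scatter) lies far beyond the scatter, whereas compound 2 and compound 3 sit within the scatter of each other, as the step of a 1.2-fold higher number from compound 2 to compound 3 (0.09 log units; within the scatter) shows, so no order between those two can be claimed.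

Compound 4 `FC(F)(F)c1ccc(Nc2nc(-c3ccccc3)nc3sc(Nc4c(Cl)cccc4Cl)nc23)cc1Cl` has not yet been measured. It differs from compound 3 at the same place: phenyl in place of methylsulfonyl on an aromatic carbon. Among the compounds with values here, two measured steps touch this position. The step of a 91-fold higher number from compound 1 to compound 3 (1.96 log units; beyond the scatter) was large, and the step of a 1.2-fold higher number from compound 2 to compound 3 (0.09 log units; within the scatter) was small. Neither step involved a phenyl, so the direction for compound 4 rests on a weak footing; a six-carbon ring is a new kind of substituent here. Since the smallest group, methyl, gave compound 1 its low number 3 nM, a lower number than that of compound 3 is expected for compound 4, as a 4.6-fold lower number from compound 3 to compound 4 (0.66 log units; beyond the scatter), though with wide uncertainty. The estimate for compound 4 in this assay is 60 nM, expected between 6 nM and 600 nM.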

Compound 4, half-maximal inhibitory concentration: 539 nM
The estimate for compound 4 lay 9.0-fold (0.95 log units) below the measured number; measured number inside the range.
By their numbers in this assay, from the lowest: compound 1; then compounds 2, 3 and 4 (each within the scatter of the next, the first and the last beyond it).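

In this assay, the step of a 2.0-fold higher number from compound 3 to compound 4 (0.29 log units; within the scatter) lies within the scatter, so methylsulfonyl, which carries hydrogen-bond acceptors and no ring, and phenyl, an aromatic ring of carbon only with no such acceptors, cannot be told apart at this aromatic carbon. Phenyl does separate from methylsulfanyl, though only modestly, with a 2.4-fold higher number from compound 2 to compound 4 (0.38 log units; beyond the scatter), and it stands far from methyl, with a 180-fold higher number from compound 1 to compound 4 (2.25 log units; beyond the scatter), so among the four groups tested here, methyl alone gives a low number, and a third kind of group has now failed to come near it. Nothing measured here explains why these groups compare as they do, and no supporting data on the cause are available.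

As far as these compounds go, what remains open is how narrow the requirement at this position is: an ethyl group, a plain hydrogen atom or an amine on the same carbon would show whether the number of compound 1, 3 nM, belongs to methyl alone or extends to other groups. From the compounds shown here alone, it is equally open whether a non-aromatic ring such as cyclohexyl, or a phenyl carrying a fluorine atom, would fall with phenyl or apart from it.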